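The source may hold more compounds than are shown below. What is called first, only, known or untested is meant among the compounds shown, and "the series" means these compounds.

Working notes on the shared core. Compound 1 `C#Cc1cn([C@@H]2O[C@H](CO)[C@@H](O)[C@H]2O)c2ncnc(NC)c12` carries ethynyl together with methylamino; compound 3 `CNc1ncnc2c1c(-c1ccccc1)cn2[C@@H]1O[C@H](CO)[C@@H](O)[C@H]1O` carries phenyl together with methylamino; compound 2 `COc1ncnc2c1c(-c1ccccc1)cn2[C@@H]1O[C@H](CO)[C@@H](O)[C@H]1O` carries phenyl together with methoxy; compound 4 `C#Cc1cn([C@@H]2O[C@H](CO)[C@@H](O)[C@H]2O)c2ncnc(OC)c12`, not yet measured, carries ethynyl together with methoxy. In a functional assay on HepG2 cells (Homo sapiens) for antiproliferative activity, read by XTT assay, with a stated time of 72 h (on this read-out lower numbers stand for stronger inhibition and higher numbers for weaker inhibition), compound 1 reaches only a limit of the assay, > 15000 nM. Compound 3 in this assay likewise reaches only a limit, > 20000 nM. Compound 2 in this assay also gives only a limit, > 20000 nM. The change ethynyl in place of phenyl on an aromatic carbon gives a step that the two limits leave unreadable from compound 3 to compound 1. The cores of compound 2 and compound 3 differ by methoxy in place of methylamino on an aromatic carbon. Compound 4 arises from compound 2 by ethynyl in place of phenyl on an aromatic carbon, the same change. For compound 4 the step that the limit leaves unreadable from compound 2 to compound 4 is expected in this assay, resting on a step that the two limits leave unreadable from compound 3 to compound 1 and on (the limit of > 20000 nM in this assay, at which 2 of the 3 values shown sit). Compound 4 is estimated at 25000 nM, between 10000 nM and 60000 nM.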

Compound 4, half-maximal inhibitory concentration: 12700 nM
Compound 4: the middle estimate sits 2.0-fold (0.29 log units) above what was measured; the range from low to high includes it.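

In this assay, ethynyl in place of phenyl on the methoxy-bearing core gives an at least 1.5-fold lower number from compound 2 to compound 4 (0.19 log units; that floor lies within the scatter), while methoxy in place of methylamino with ethynyl kept gives an at least 1.1-fold lower number from compound 1 to compound 4 (0.07 log units; that floor lies within the scatter). Both figures are floors lying within the scatter, so neither change is shown to exceed it, although the true steps may be larger. The steps among compound 1, compound 2 and compound 3 cannot be read, so carrying the ethynyl change from the methylamino-bearing core to the methoxy-bearing core is neither confirmed nor refuted, and the reading is held back by the limit: the limit of > 20000 nM in this assay, at which 2 of the 4 values shown sit.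

On these data alone, whether a longer chain or an amine on that aromatic carbon would give a step clear of the scatter stays open. Also open, as far as these compounds go, is whether a carboxylic acid there would do so on either core.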